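The source may report more compounds than this note shows. Statements on the series, on what has been measured and on what is new or still open speak of the compounds shown alone.

Measured so far:

Compound 1, `O=C(CN(c1nc(Cl)nc2[nH]cnc12)C1CC1)NCC(=O)OCc1ccccc1`: 21.7%
Compound 2, `N=C(N)NCCC[C@H](NC(=O)CN(c1nc(Cl)nc2[nH]cnc12)C1CC1)C(=O)O`: 17%
Compound 3, `O=C(CN(c1ncnc2c1ncn2C1CCCCO1)C1CC1)N[C@@H](CCC(=O)OCc1ccccc1)C(=O)OCc1ccccc1`: 20.7%

All three compounds were tested in a functional assay on the whole organism (Tail, strain ICR) with Mus musculus as the target, in the tail flick test, with a stated time of 120 min, at a dose of 25 umol/kg by the oral route; a higher number here means a stronger effect of the compound at the dose given, a lower number a weaker effect. In this assay compound 1 gives 21.7%, the highest of the three numbers. The nearest is compound 3 with 20.7%, and the furthest is compound 2 with 17%; both of these gaps lie within the usual scatter, so the three compounds cannot be ranked against one another on these numbers.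

The next compound, compound 4, `NCCCC[C@H](NC(=O)CN(c1nc(Cl)nc2[nH]cnc12)C1CC1)C(=O)OCc1ccccc1`, has not yet been measured in this assay. It differs from compound 1 in one place: 4-aminobutyl in place of hydrogen on a saturated chain carbon bound to an amide-type nitrogen and a carbonyl carbon. The 4-aminobutyl group enters on a saturated chain carbon bound to an amide-type nitrogen and a carbonyl carbon, where compound 1 carries only a hydrogen.

Within the data shown here, no measured pair in this set differs in just one place, so there is no directly comparable step to lean on. Compound 2 and compound 3 also carry chains on that position and give values within the scatter of compound 1, which gives no sign of a shift in either direction. The expected step of a number 1.7 percentage points lower from compound 1 to compound 4 (within the scatter) is therefore none beyond the scatter. Compound 4 is estimated to give about 20% in this assay, with a range from 8% to 32%.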

Compound 4, a percentage reported as activity, at one dose (the size of the read-out at that dose, not a potency): 16.8%
For compound 4 the middle estimate is 3.2 percentage points above the measured one, and the stated range covers the measured number.
By their numbers in this assay, from the lowest: compounds 4, 2, 3 and 1 (each within the scatter of the next).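

Swapping hydrogen for 4-aminobutyl on the saturated chain carbon bound to an amide-type nitrogen and a carbonyl carbon gives a number 4.9 percentage points lower from compound 1 to compound 4 (within the scatter) in this assay. Among these compounds, this is the first pair in the set that differs in only one place, so it is the first direct reading of this position: a group of 5 heavy atoms with no ring can be placed there without a change that stands out from the scatter at this dose. No measurement shown here accounts for this result.

The compounds shown leave open whether a much smaller group on this carbon, such as methyl, or a longer chain carrying an amine would move the number beyond the scatter. On these data alone, because the read-out comes from a single dose and a single time point, it also remains open whether compound 1 and compound 4 would still be indistinguishable at a higher dose, where a difference between them might be easier to see.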